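The compounds below may be only part of what the source reports. "The series", "measured", "known", "first", "only" and "open" are said of these compounds alone.

Compound 1 `O=C(NCCCNc1nccc(-c2c(-c3cccc(F)c3)nc3sccn23)n1)c1ccc(Cl)cc1` is tested in a functional assay on A-375 cells (Homo sapiens) for cytotoxicity, read by MTT assay (a higher number here means a weaker inhibitor, a lower number a stronger inhibitor), where compound 1 gives 13700 nM. Within the data shown here, compound 2 `O=S(=O)(NCCNc1nccc(-c2c(-c3cccc(F)c3)nc3sccn23)n1)c1ccc(C(F)(F)F)cc1`, the only other measured compound, gives 7440 nM in this assay; the two numbers lie within the usual scatter of each other, so neither stands apart. Compound 3 `O=S(=O)(NCCCNc1nccc(-c2c(-c3cccc(F)c3)nc3sccn23)n1)c1ccc(F)cc1` differs from compound 1 by (4-fluorophenyl)sulfonyl in place of (4-chlorophenyl)carbonyl on an amine nitrogen. Among the measured compounds shown here, no measured pair shows this change, and compound 2 shares only the sulfonyl part with a different chain. The estimate is for a step of a 1.4-fold lower number from compound 1 to compound 3 (0.16 log units; within the scatter) from compound 1 to compound 3, no larger than the scatter. Compound 3 is expected to give 9500 nM in this assay, within 3000 nM to 30000 nM.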

Compound 3, half-maximal inhibitory concentration: 14500 nM
For compound 3 the middle estimate is 1.5-fold (0.18 log units) below the measured one; measured number inside the range.
By their numbers in this assay, from the lowest: compounds 2, 1 and 3 (each within the scatter of the next).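

In this assay, among these compounds, (4-fluorophenyl)sulfonyl in place of (4-chlorophenyl)carbonyl on an amine nitrogen gives a 1.1-fold higher number from compound 1 to compound 3 (0.02 log units; within the scatter), the first direct reading of this change. At this position, on this chain, the two groups are not told apart, although the pair changes both the linking group and the ring halogen. Nothing measured here bears on the result. Going by these compounds, whether the two changes each do nothing or offset one another stays open. So does what (4-chlorophenyl)sulfonyl, (4-fluorophenyl)carbonyl or a longer chain would give.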